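This account rests on a few compounds, and the source may have more. Where it says the series, first, only, none or still open, it means among the compounds named here.

Measured compounds:
Compound 1 `C=C1CN(C)N(c2ccc(Cl)cc2)C1=O` gives 45200 nM in a functional assay on MCF7 cells (Homo sapiens) for inhibition, read by MTT assay, with a stated time of 48 h; on this read-out lower numbers stand for stronger inhibition and higher numbers for weaker inhibition.
Compound 2 `C=C1C(=O)N(c2ccccc2)N(c2ccccc2)C1c1ccccc1` gives 4500 nM in this assay.
Compound 3 `C=C1C(=O)N(c2ccccc2)N(C)C1CCCCCCCCC` gives 91100 nM in this assay.

Among these three, compound 2 stands lowest in this assay, well clear of the scatter from both compound 1 and compound 3. Compound 4 `C=C1C(=O)N(c2ccccc2)N(c2ccccc2)C1C` is not yet measured. It differs from compound 2 in one place: methyl in place of phenyl on a saturated ring carbon. Going by the values given here, no measured pair shows this exact change, so the step must be judged from what the three measured compounds show. Compound 1 and compound 3, which lack a phenyl on the shared core at that position, both give higher numbers than compound 2. The step from compound 2 to compound 4 is therefore expected to move upward, beyond the scatter, by a 3.3-fold higher number from compound 2 to compound 4 (0.52 log units; beyond the scatter). Compound 4 is estimated at 15000 nM, with a likely range from 5000 nM to 50000 nM.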

Compound 4, half-maximal inhibitory concentration: 12500 nM
Beside the measured number, compound 4's estimate is 1.2-fold (0.08 log units) above it, and the stated range covers the measured number.
By their numbers in this assay, from the lowest: compound 2; then compound 4; then compounds 1 and 3 (each within the scatter of the next).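

Going by these compounds alone, this gives the first direct reading of this position on the shared core: with methyl in place of phenyl on the saturated ring carbon, this assay shows a 2.8-fold higher number from compound 2 to compound 4 (0.44 log units; beyond the scatter). The step lies beyond the scatter but is modest, so the phenyl at this carbon is not essential for a measurable effect in these cells. Nothing available here explains the rise. Still open, as far as these compounds go, is how an ethyl group, a longer chain, a benzyl group or an amine would read at this carbon. A substituted phenyl, such as 4-chlorophenyl, is also untested here.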